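The source may hold more compounds than are shown below. What is called first, only, known or untested is meant among the compounds shown, and "the series" means these compounds.

For the measured compounds named here, compound 2 `CN(Cc1ccccc1)CC1CCN(CCCc2c[nH]c3ccc(-n4cnnc4)cc23)CC1` gives 0.9 nM in an assay on CHO cells for displacement of a labelled ligand from 5-hydroxytryptamine receptor 1D (Homo sapiens) (on this read-out lower numbers stand for stronger inhibition and higher numbers for weaker inhibition), the lowest of the two numbers measured so far. Going by the values given here, compound 1 `CN(Cc1cccs1)C1CCN(CCCc2c[nH]c3ccc(-n4cnnc4)cc23)CC1` gives 4.3 nM in this assay, and the step of a 4.8-fold lower number from compound 1 to compound 2 (0.68 log units; beyond the scatter) is the only measured step available. Compound 3 `C[C@H](NCC1CCN(CCCc2c[nH]c3ccc(-n4cnnc4)cc23)CC1)c1ccccc1` differs from compound 2 by (1-phenylethyl)amino in place of benzyl(methyl)amino on a saturated chain carbon bound to a saturated ring carbon; the methyl that sat on the nitrogen now sits on the carbon that carries the phenyl ring, so the two compounds share the same atoms in a different arrangement. Among the compounds with values here, no measured step covers a rearrangement of this kind, and the step from compound 1 to compound 2 altered a different part of the molecule, so it offers no guide here. The number for compound 3 is therefore expected to stay close to that of compound 2, with a 1.4-fold higher number from compound 2 to compound 3 (0.16 log units; within the scatter) as the expected step at most. Compound 3 is estimated at 1.3 nM, within a range from 0.3 nM to 5 nM.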

Compound 3, half-maximal inhibitory concentration: 4.4 nM
The estimate for compound 3 lay 3.4-fold (0.53 log units) below the measured number; measured number inside the range.
By their numbers in this assay, from the lowest: compound 2; then compounds 1 and 3 (each within the scatter of the next).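

In this assay, moving the methyl from the nitrogen to the carbon that carries the phenyl ring is no neutral reshuffle of the same atoms: the change gives a 4.9-fold higher number from compound 2 to compound 3 (0.69 log units; beyond the scatter). This swap of benzyl(methyl)amino for (1-phenylethyl)amino also adds a hydrogen-bond donor and a defined stereocentre, and nothing on hand says which difference, if either, lies behind the step.
The other step, a 1.0-fold higher number from compound 1 to compound 3 (0.01 log units; within the scatter), puts compound 3 level with compound 1, so the low number of compound 2 does not survive the rearrangement.

Still open, as far as these compounds go, is whether a methyl(1-phenylethyl)amino group, with a methyl on both the nitrogen and the carbon, would recover the number of compound 2. The compounds shown also leave open how the mirror-image form of the (1-phenylethyl)amino group would behave.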